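The compounds below may be only part of what the source reports. "The series", "measured", "known", "first", "only" and "open" are said of these compounds alone.

Compound 2 (`COc1ccc(C(=O)Nc2ncnc3nn(Cc4ccccc4)cc23)cc1`) has been tested in an assay on CHO cells for displacement of a labelled ligand from adenosine receptor A1 (Homo sapiens) (a lower number here means a stronger inhibitor, a higher number a weaker inhibitor), and gives > 10000 nM, which is a limit of the assay rather than a number. Compound 1 (`COc1ccc(NC(=O)Nc2nc(-c3ccccc3)nc3nn(C)cc23)cc1`) likewise gives > 10000 nM in this assay, again a limit. Both measured values sit at the limit of > 10000 nM in this assay, at which 2 of the 2 values shown sit. Compound 3 (`O=C(Nc1ncnc2nn(Cc3ccccc3)cc12)c1cccc(Cl)c1`) differs from compound 2 by 3-chlorophenyl in place of 4-methoxyphenyl on a carbonyl carbon. Within the data shown here, no measured step between two compounds is available to guide this change, so no shift beyond the usual scatter is expected, and compound 3 is expected to give 15000 nM (range 3000 nM to 60000 nM). The expected step that the limit leaves unreadable from compound 2 to compound 3 is thus small.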

Compound 3, inhibition constant: > 10000 nM
Compound 3 gave a limit, no number; the forecaster's own chance of this, stated with the estimate: 70%; the middle value does not contradict the limit.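

No step can be read from compound 2 to compound 3: each gives only a limit, not a number. The compounds shown leave open how strongly any of them binds, and whether 3-chlorophenyl in place of 4-methoxyphenyl changes that at all.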